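This account rests on a few compounds, and the source may have more. Where it says the series, first, only, none or still open, it means among the compounds named here.

Working notes on the series. Compound 1 `C[C@@H]1CN(c2cccc3c2C[C@H](CN(C)[C@H]2CCCc4cccnc42)NC3)C[C@H](C)N1`, compound 2 `CCN(C[C@H]1Cc2c(cccc2N2CCNCC2)CN1)[C@H]1CCCc2cccnc21` and compound 3 `CN(C[C@H]1Cc2c(cccc2N2CCN(c3cccc(C(F)(F)F)c3)CC2)CN1)[C@H]1CCCc2cccnc21` share one core and differ only in the groups attached to it. In a functional assay on CCRF-CEM cells for agonist activity at C-X-C chemokine receptor type 4 (Homo sapiens), read by calcium flux, with a stated time of 25 min (a lower number here means that less compound is needed, a higher number that more compound is needed for the effect), compound 1 gives > 30000 nM, which is a limit of the assay and not a number. Compound 2 in this assay gives > 30000 nM, again a limit. Compound 3 in this assay gives > 30000 nM, also a limit. Where compound 3 stands is thus set only by the limit of > 30000 nM in this assay, at which 3 of the 3 values shown sit; no measured step between any two of these compounds exists, and no order among them can be read from the numbers.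

Compound 4 `CN(C[C@H]1Cc2c(cccc2N2CCNCC2)CN1)[C@H]1CCCc2cccnc21` is not yet measured. It differs from compound 3 by hydrogen in place of 3-(trifluoromethyl)phenyl on an amine nitrogen in a ring. Compound 2 also carries hydrogen on that ring nitrogen and in this assay gives > 30000 nM, a limit. On that basis the expected step is a step that the limit leaves unreadable from compound 3 to compound 4, no change beyond the scatter in either direction. For compound 4 the estimated value in this assay is 40000 nM, with a range from 10000 nM to 150000 nM, and most likely the assay will again report only a limit.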

Compound 4, half-maximal effective concentration: > 30000 nM
Compound 4: no number, only a limit; the forecaster's own chance of this, stated with the estimate: 85%; the middle value is on the limit's open side.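

In this assay compound 4 gives > 30000 nM, again a limit and not a number. No step from compound 1, compound 2 or compound 3 to compound 4 can be read: the limit of > 30000 nM in this assay, at which 4 of the 4 values shown sit.

The compounds shown leave open whether any group on the shared core gives a measurable value in this assay.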